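Para tert-butyl on the benzyl ring of compound 3

A few compounds are considered here, and "the series" means these few. Any claim that something is new, unique, unknown or untested is made for them only; others in the source may bear on it.

Measured compounds:
compound 1, `C=C(Br)C(=O)Nc1cccc(/C=C2\SC(=O)N(Cc3ccc(Cl)cc3)C2=O)c1`, 1600 nM
compound 2, `C=C(Br)C(=O)Nc1cccc(/C=C2\SC(=O)N(Cc3cccc(Cl)c3)C2=O)c1`, 1700 nM
compound 3, `C=C(Br)C(=O)Nc1cccc(/C=C2\SC(=O)N(Cc3ccccc3)C2=O)c1`, 810 nM

All three were read in a functional assay on FM3A cells (Mus musculus) for cytotoxicity, read by cell counting, with a stated time of 2 days; a higher number here means a weaker inhibitor, a lower number a stronger inhibitor. Compound 3 is set apart from compound 2 by a step beyond the scatter a 2.1-fold lower number from compound 2 to compound 3 (0.32 log units; beyond the scatter), while its step from compound 1 stays within it a 2.0-fold lower number from compound 1 to compound 3 (0.30 log units; within the scatter); the two chloro compounds do not separate a 1.1-fold higher number from compound 1 to compound 2 (0.03 log units; within the scatter).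

Compound 4, `C=C(Br)C(=O)Nc1cccc(/C=C2\SC(=O)N(Cc3ccc(C(C)(C)C)cc3)C2=O)c1`, is the next entry. Its difference from compound 3 is tert-butyl in place of hydrogen on an aromatic carbon. For the measured compounds named here, no measured step introduces this group; the two steps that touch the same aromatic ring, a 2.0-fold lower number from compound 1 to compound 3 (0.30 log units; within the scatter) and a 2.1-fold lower number from compound 2 to compound 3 (0.32 log units; beyond the scatter), remove chloro and are modest at most. A substituent on that ring so far gave only a small rise in the number, and tert-butyl is expected to behave in the same range: a small rise a 1.9-fold higher number from compound 3 to compound 4 (0.27 log units; within the scatter), largely within the scatter. Compound 4 is therefore estimated at 1500 nM, between 600 nM and 4000 nM.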

Compound 4, half-maximal inhibitory concentration: 5200 nM
For compound 4 the middle estimate is 3.5-fold (0.54 log units) below the measured one; measured number outside the range, above it.
By their numbers in this assay, from the lowest: compounds 3, 1 and 2 (each within the scatter of the next, the first and the last beyond it); then compound 4.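

Tert-butyl on this aromatic carbon gives a clear rise in this assay (a 6.4-fold higher number from compound 3 to compound 4 (0.81 log units; beyond the scatter)), so this ring does not accept every substituent with only the small changes seen for chloro. The choice of group also matters, as tert-butyl separates from chloro on the same carbon (a 3.3-fold higher number from compound 1 to compound 4 (0.51 log units; beyond the scatter)) and 4-(tert-butyl)phenyl separates from 3-chlorophenyl (a 3.1-fold higher number from compound 2 to compound 4 (0.49 log units; beyond the scatter)), whereas the two chloro compounds do not separate from each other. Nothing available here accounts for the rise.

The compounds shown leave open whether methyl or isopropyl on this carbon already raises the number, or whether the rise appears only with tert-butyl. Also open, as far as these compounds go, is whether an amine or a carboxylic acid at this place would track chloro, tert-butyl or neither.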